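From 4-chlorophenyl to pyridin-2-yl on a shared core

The source may hold more compounds than are shown below. What is called first, only, known or untested is meant among the compounds shown, and "the series" means these compounds.

Measured in a functional assay on K562 cells (Homo sapiens) for cytotoxicity, read by ELISA, with a stated time of 4 days; on this read-out lower numbers stand for stronger inhibition and higher numbers for weaker inhibition:
Compound 1 `Clc1ccc(-c2cc(-c3ccoc3)cc(-c3ccccc3Cl)n2)s1`: 15800 nM
Compound 2 `Clc1ccc(-c2cc(-c3ccoc3)cc(-c3ccc(Cl)s3)n2)cc1`: 19600 nM

In this assay compound 2 gives 19600 nM, which lies within the scatter of compound 1, so the two cannot be ranked. Compound 3 `Clc1ccc(-c2cc(-c3ccoc3)cc(-c3ccccn3)n2)s1` has not yet been measured. It differs from compound 2 by pyridin-2-yl in place of 4-chlorophenyl on an aromatic carbon.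

Going by the values given here, only one measured step bears on this change, and it does so indirectly. That step is a 1.2-fold higher number from compound 1 to compound 2 (0.09 log units; within the scatter), with 4-chlorophenyl in place of 2-chlorophenyl on an aromatic carbon. Among the compounds with values here, it stays within the scatter, but it compares two chlorophenyl groups, and no measured compound carries pyridin-2-yl. The data therefore give no direction for the change, and no step beyond the scatter is expected, though this expectation is loosely supported. The expected step is a 1.3-fold lower number from compound 2 to compound 3 (0.12 log units; within the scatter). For compound 3 the estimated value is 15000 nM, with an expected range from 5000 nM to 40000 nM.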

Compound 3, half-maximal inhibitory concentration: 20000 nM
For compound 3 the middle estimate is 1.3-fold (0.12 log units) below the measured one, within the range that was stated.
By their numbers in this assay, from the lowest: compounds 1, 2 and 3 (each within the scatter of the next).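

With pyridin-2-yl, this position, on the aromatic carbon next to the ring nitrogen, now holds a ring other than a chlorophenyl, and the read-out in this assay still does not separate the compounds. Replacing 4-chlorophenyl gives a 1.0-fold higher number from compound 2 to compound 3 (0.01 log units; within the scatter), and replacing 2-chlorophenyl gives a 1.3-fold higher number from compound 1 to compound 3 (0.10 log units; within the scatter), so neither step can be told from repeated measurement. Across these three compounds, then, the position tolerates the loss of the chlorine and the entry of a ring nitrogen with one hydrogen-bond acceptor without a readable change in the number, although no measurement available here offers an explanation for this.

The compounds shown leave open whether any group at this position can move the value beyond the scatter, for instance a ring bearing an amine or a carboxylic acid, or a saturated ring such as piperidine in place of the aromatic one. They also leave open what the furan-3-yl and 5-chlorothiophen-2-yl groups contribute, since both stay the same across all three compounds.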